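The compounds below may be only part of what the source reports. "The series", "measured", "known", "first", "only" and "open" are said of these compounds alone.

Compound 1 `CCN(CC)CCn1c(N)c(-c2nc3ccccc3[nH]2)c2nc(C#N)c(C#N)nc21` gives 12200 nM in an ADME assay on HEK293 cells (Homo sapiens) for cytotoxicity, read by MTT assay, with a stated time of 48 h; a lower number here means a stronger inhibitor, a higher number a weaker inhibitor.
Compound 2 `CCCn1c(N)c(-c2nc3ccccc3[nH]2)c2nc(C#N)c(C#N)nc21` gives > 50000 nM in this assay, which is a limit of the assay rather than a number.

Among the measured compounds shown here, compound 1 holds the only number given in this assay; the value for compound 2 is a limit (the limit of > 50000 nM in this assay, at which 1 of the 2 values shown sits). For the measured compounds named here, the one measured step, an at least 4.0-fold higher number from compound 1 to compound 2 (0.61 log units; beyond the scatter), shows that when the diethylamino is taken away and a methyl stands in its place, the number rises beyond the scatter. So the diethylamino on the chain seems to matter for the number that compound 1 gives.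

Compound 3 `CN1CCN(CCCn2c(N)c(-c3nc4ccccc4[nH]3)c3nc(C#N)c(C#N)nc32)CC1` is not yet measured. It differs from compound 1 by (4-methylpiperazin-1-yl)methyl in place of diethylamino on a saturated chain carbon, two bonds along the chain from an aromatic nitrogen. Unlike compound 2, compound 3 keeps a basic nitrogen on the chain, and gains a further one within the ring. The step from compound 1 to compound 2 therefore bears on it only in part: it tells what happens when the amine is lost, not what happens when it is exchanged for a larger one. The expectation is that compound 3 stays close to compound 1, with a step of a 1.0-fold lower number from compound 1 to compound 3 (0.01 log units; within the scatter) that need not go beyond the scatter in either direction. Compound 3 is thus estimated at 12000 nM, between 4000 nM and 40000 nM.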

Compound 3, half-maximal inhibitory concentration: 6260 nM
Compound 3: middle estimate off by 1.9-fold (0.28 log units), on the high side; low and high end bracket the measured number.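

In this assay, the exchange of diethylamino for (4-methylpiperazin-1-yl)methyl gives a 1.9-fold lower number from compound 1 to compound 3 (0.29 log units; within the scatter), so this position on the chain takes a larger amine that contains a ring without a change that stands out from the scatter. Measured against the chain with no amine, 4-methylpiperazin-1-yl in place of hydrogen gives an at least 7.9-fold lower number from compound 2 to compound 3 (0.90 log units; beyond the scatter), so a second, different amine now shows the same direction that until now rested on the diethylamino alone. The value of compound 2 is a limit and not a number, so the full size of that step stays unknown: the limit of > 50000 nM in this assay, at which 1 of the 3 values shown sits.

The compounds shown leave open how much the nitrogen itself counts, which a morpholine or a simple primary amine on the same chain could help to separate. They also leave chain length and amine tied together, since the 2-(diethylamino)ethyl to 3-(4-methylpiperazin-1-yl)propyl change alters both at once, and a 2-(4-methylpiperazin-1-yl)ethyl chain would pull the two apart.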